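Replacing the Vinylcarbonyl Group in a Growth Inhibition Series

The source may report more compounds than this note shows. Statements on the series, on what has been measured and on what is new or still open speak of the compounds shown alone.

Of the compounds shown here, three sharing one core have been tested in an ADME assay on BaF3 cells (Mus musculus) for cytotoxicity, read by CellTiter-Glo and CCK-8 assay, with a stated time of 72 h; a lower number here means a stronger inhibitor of growth, a higher number a weaker inhibitor of growth. Going by the values given here, compound 2 `C=CC(=O)Nc1ccc(C(=O)Nc2ccc(C)c(Nc3nccc(-c4cccnc4)n3)c2)cc1` gives 5600 nM, the higher of the two actual numbers so far. Compound 3 `C=CC(=O)Nc1cccc(C(=O)Nc2ccc(C)c(Nc3nccc(-c4cccnc4)n3)c2)c1` gives 2480 nM. Compound 1 `C=CC(=O)NCc1ccc(C(=O)Nc2ccc(C)c(Nc3nccc(-c4cccnc4)n3)c2)cc1C(F)(F)F` gives > 10000 nM, which is a limit of the assay and not a number. This is the limit of > 10000 nM in this assay, at which 1 of the 3 values shown sits.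

The next structure is compound 4 `Cc1ccc(NC(=O)c2ccc(CN(CCN(C)C)C(=O)C3CC3)cc2)cc1Nc1nccc(-c2cccnc2)n1`, and the change is ((cyclopropylcarbonyl)(2-(dimethylamino)ethyl)amino)methyl in place of (vinylcarbonyl)amino on an aromatic carbon. The (vinylcarbonyl)amino group leaves, and a larger ((cyclopropylcarbonyl)(2-(dimethylamino)ethyl)amino)methyl group enters at the same place.

Among the compounds with values here, only one measured step bears on this directly: a 2.3-fold lower number from compound 2 to compound 3 (0.35 log units; beyond the scatter). That step is modest, and it swaps 4-((vinylcarbonyl)amino)phenyl for 3-((vinylcarbonyl)amino)phenyl, so the group stays in the molecule. Within the data shown here, no measured compound carries the entering group, which leaves the direction of any change open. With so little to go on, the best guess is no shift beyond the scatter, held with wide uncertainty. The expected move is a 1.1-fold lower number from compound 2 to compound 4 (0.05 log units; within the scatter). For compound 4 the estimated value in this assay is 5000 nM, with an expected range from 1800 nM to 10000 nM.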

Compound 4, concentration for 50% growth inhibition: > 10000 nM
Compound 4 was reported as a limit; the forecaster's own chance of this, stated with the estimate: 25%; middle value at least 2.0-fold (0.30 log units) away from the limit.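

this assay reports compound 4 as a limit of the assay and not a number: the limit of > 10000 nM in this assay, at which 2 of the 4 values shown sit.

Until now, the changes at this part of the molecule kept the (vinylcarbonyl)amino group, and the step from compound 2 to compound 3 only moved it around the ring. Going by these compounds alone, this result is the first view of that aromatic carbon, para to a large group, without the group, and the larger ((cyclopropylcarbonyl)(2-(dimethylamino)ethyl)amino)methyl group brings no gain in growth inhibition that can be read. The step is an at least 1.7-fold higher number from compound 2 to compound 4 (0.25 log units; that floor lies within the scatter), and since this figure is only a floor, the true gap could be wider, but the data cannot show that the swap made compound 4 weaker than compound 2.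

Going by these compounds, the cyclopropylcarbonyl part and the 2-(dimethylamino)ethyl chain enter together, so it remains open which of them, if either, matters for this reading. Also open, on these data alone, is how a much smaller group on the same carbon, such as a plain aminomethyl or a carboxylic acid, would read in this assay.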